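The compounds below may be only part of what the source reports. "The series", "measured", "known", "first", "only" and "open" are said of these compounds alone.

Measured so far:
compound 1, `CC#CC(CC(=O)O)c1ccc(OCc2ccn3cc(-c4ccc(C(C)C)cc4)nc3c2)cc1`, giving 615 nM in an assay on isolated protein for agonist activity at Free fatty acid receptor 1 (Homo sapiens); a higher number here means that more compound is needed for the effect, a lower number that less compound is needed
compound 2, `CC#CC(CC(=O)O)c1ccc(OCc2ccc3nc(-c4ccccc4)cn3c2)cc1`, giving 979 nM in this assay

Compound 2 and compound 1 give numbers in this assay that lie within the usual scatter of each other, so no ranking between them is claimed. Compound 3, `CC#CC(CC(=O)O)c1ccc(OCc2ccc3nc(-c4ccc(C)cc4C)cn3c2)cc1`, differs from compound 2 by 2,4-dimethylphenyl in place of phenyl on an aromatic carbon. Among the measured compounds shown here, no measured pair shows this change, and the two measured values hardly separate, so the step of a 1.3-fold lower number from compound 2 to compound 3 (0.12 log units; within the scatter) is expected to remain within the scatter, with no set direction. In this assay compound 3 is expected near 750 nM, in the range 250 nM to 2200 nM.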

Compound 3, half-maximal effective concentration: 316 nM
For compound 3 the middle estimate is 2.4-fold (0.38 log units) above the measured one; the range from low to high includes it.
By their numbers in this assay, from the lowest: compounds 3, 1 and 2 (each within the scatter of the next, the first and the last beyond it).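

In this assay, among the compounds shown here, 2,4-dimethylphenyl in place of phenyl on the aromatic carbon of the five-membered aromatic ring gives a 3.1-fold lower number from compound 2 to compound 3 (0.49 log units; beyond the scatter) and is the first single-place step available. The aryl group at this position therefore affects the read-out, which compounds 1 and 2 could not show, as they differ in more than one place. No measurement shown here bears on the reason for this step.

Whether one methyl alone would account for the step remains open. So does the outcome with a chloro, methoxy or amine substituent on this phenyl ring.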